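A Small Alcohol Chain Replaces a Ring on the Amide Nitrogen

This account rests on a few compounds, and the source may have more. Where it says the series, first, only, none or still open, it means among the compounds named here.

Compound 1 `Cc1ccc(OCC(=O)N(Cc2cccs2)c2cnn(C)c2)cc1` is the weakest of the three measured compounds: in an assay on HEK293 cells for agonist activity at transient receptor potential cation channel subfamily M member 8 (Homo sapiens), read by fluorescence and calcium flux, with a stated time of 15 min (on this read-out higher numbers stand for an effect only at larger amounts of compound and lower numbers for an effect already at smaller amounts), compound 1 gives 63000 nM, while compound 2 `CCN(Cc1cccs1)C(=O)COc1ccc(C(C)C)cc1` gives 397 nM and compound 3 `CCN(Cc1cccs1)C(=O)/C=C/c1ccc(C)cc1` gives 2 nM, both well beyond the usual scatter from compound 1. Compound 4 `Cc1ccc(OCC(=O)N(CCO)Cc2cccs2)cc1` differs from compound 1 in a single spot: 2-hydroxyethyl in place of 1-methyl-1H-pyrazol-4-yl on an amide-type nitrogen. Neither compound 2 nor compound 3 carries a ring of this kind on its amide-type nitrogen, and both sit far below compound 1, so a shift toward smaller numbers is expected. The expected step of an 11-fold lower number from compound 1 to compound 4 (1.02 log units; beyond the scatter) is estimated to be sizeable, because compound 2 gives 397 nM without such a ring. Compound 4 is expected to give about 6000 nM, with a likely range from 1000 nM to 30000 nM.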

Compound 4, half-maximal effective concentration: 900 nM
Compound 4: middle estimate off by 6.7-fold (0.82 log units), on the high side; the whole stated range lies above it.
By their numbers in this assay, from the lowest: compound 3; then compound 2; then compound 4; then compound 1.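

Among the compounds shown here, this is the first pair in which only the group on the amide-type nitrogen changes, so the position alone can be judged. In this assay, replacing 1-methyl-1H-pyrazol-4-yl with 2-hydroxyethyl gives a 70-fold lower number from compound 1 to compound 4 (1.85 log units; beyond the scatter), which shows that the core of compound 1 does not need a ring at this position and that this position strongly affects the read-out. No measurement shown explains the size of this step. Going by these compounds, it also remains open whether a longer chain such as 3-hydroxypropyl, or an amine such as 2-aminoethyl, would lower the number further or raise it.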